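Carbamate series: methoxy for chloro on the phenyl carbamate

This account rests on a few compounds, and the source may have more. Where it says the series, first, only, none or still open, it means among the compounds named here.

Measured compounds in the series:
compound 1, `NC(=O)OC(CCN1CCN(c2ccccc2)CC1)c1cccc(Cl)c1` — 59%
compound 2, `COc1ccc(N2CCN(CCC(OC(N)=O)c3ccc(Cl)cc3)CC2)cc1` — 51%
compound 3, `COc1cc(OC)cc(N2CCN(CCC(OC(N)=O)c3ccccc3)CC2)c1` — 13%

The read-out throughout is a functional assay on the whole organism for inhibition, with Mus musculus as the target, in the writhing test, with a stated time of 1 h, at a dose of 10 mg/kg by the oral route; a higher number here means more inhibition at the dose given (going by the name of the read-out), a lower number less inhibition. Compound 1 gives 59%. Compound 2 gives 51%, the second highest of the three numbers; its nearest neighbour is compound 1, which lies within the scatter of it, so no order between compound 1 and compound 2 can be read from this assay. Among the compounds with values here, compound 3 gives 13%, well below compound 2 and beyond the scatter, but compound 3 differs from compound 2 in more than one place, so no single-point step is available in the set.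

Compound 4, `COc1ccc(C(CCN2CCN(c3ccc(OC)cc3)CC2)OC(N)=O)cc1`, is not yet measured in this assay. It departs from compound 2 by methoxy in place of chloro on an aromatic carbon. The same difference, cut one bond further out, reads 4-chlorophenyl to 4-methoxyphenyl.

Within the data shown here, no measured pair isolates this change, so its size is unknown. With compound 1 and compound 2 within the scatter of each other and compound 3 far lower after a different change, the expectation for compound 4 is a moderate drop, with the step from compound 2 estimated as a number 11 percentage points lower from compound 2 to compound 4 (beyond the scatter). In this assay compound 4 is expected to give 40%, within a range from 20% to 60%.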

Compound 4, a percentage reported as inhibition, in the whole organism at one dose (the size of the read-out at that dose, not a potency): 53%
Estimate against measurement, compound 4: 13 percentage points below, and the stated range covers the measured number.
By their numbers in this assay, from the lowest: compound 3; then compounds 2, 4 and 1 (each within the scatter of the next).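

In this assay, within the data shown here, the change from 4-chlorophenyl to 4-methoxyphenyl gives the first single-point step, a number 2 percentage points higher from compound 2 to compound 4 (within the scatter) at this position, on an aromatic carbon para to a large group. At this position methoxy therefore stands in for chloro with no difference the read-out can resolve, even though one more heavy atom and a hydrogen-bond acceptor enter with it. This rests on a single pair on one background and on one oral dose, so it describes the size of the read-out at that dose and not a potency.

No measured evidence at hand explains why the two groups read alike.

As far as these compounds go, whether fluoro, trifluoromethyl, a hydroxyl or a carboxylic acid at this position would also read alike remains open. From the compounds shown here alone, it is also open whether the same swap behaves this way on a different background, and compound 3 differs from each of the other compounds in more than one place, so the steps to it cannot be read.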